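Methoxy in Place of Fluoro on the Shared Core

The source may report more compounds than this note shows. Statements on the series, on what has been measured and on what is new or still open speak of the compounds shown alone.

Measured so far in an ADME assay on NIH3T3 cells (Mus musculus) for cytotoxicity, read by MTT assay, with a stated time of 24 h; a lower number here means a stronger inhibitor, a higher number a weaker inhibitor:
Compound 1, `COc1ccc(-c2cs/c(=N/NC(=O)CSc3nnnn3-c3ccccc3)n2-c2ccccc2)cc1`, gives 11.7 ug/mL.
Compound 2, `Cn1cnnc1SCC(=O)N/N=c1/scc(-c2ccc([N+](=O)[O-])cc2)n1-c1ccccc1`, gives 133 ug/mL.
Compound 3, `Cn1cnnc1SCC(=O)N/N=c1/scc(-c2ccc(F)cc2)n1-c1ccccc1`, gives 65 ug/mL.

Among these three numbers compound 3 stands second highest, with compound 2 nearest and compound 1 furthest away. Compound 4, `COc1ccc(-c2cs/c(=N/NC(=O)CSc3nncn3C)n2-c2ccccc2)cc1`, carries one change relative to compound 3: methoxy in place of fluoro on an aromatic carbon. Among the compounds with values here, no measured step swaps exactly these two groups. Within the data shown here, the only step at this place, a 2.0-fold lower number from compound 2 to compound 3 (0.31 log units; beyond the scatter), was modest. Compound 1 also carries a methoxy group and gives 11.7 ug/mL, but it differs from compound 4 elsewhere too, so it guides only loosely. A modest lowering in this assay is therefore expected, a 1.6-fold lower number from compound 3 to compound 4 (0.21 log units; within the scatter). Compound 4 is estimated at 40 ug/mL, within 15 ug/mL to 110 ug/mL.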

Compound 4, half-maximal inhibitory concentration: 167 ug/mL
Estimate against measurement, compound 4: 4.2-fold (0.62 log units) below; measured number above the stated range.
By their numbers in this assay, from the lowest: compound 1; then compound 3; then compounds 2 and 4 (each within the scatter of the next).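

In this assay, methoxy on this aromatic carbon shifts the number the opposite way from what the earlier step suggested, a 2.6-fold higher number from compound 3 to compound 4 (0.41 log units; beyond the scatter), while a 1.3-fold higher number from compound 2 to compound 4 (0.10 log units; within the scatter) leaves methoxy and nitro within the scatter of each other, so fluoro alone stands apart among these three groups. With methoxy held fixed, the group on the sulfur makes the largest step seen, a 14-fold higher number from compound 1 to compound 4 (1.15 log units; beyond the scatter), so methoxy alone does not carry the low number of compound 1.

Nothing measured here gives a reason for these steps. Still open is how an amine on this aromatic carbon would read, and whether 4-fluorophenyl keeps its place among these groups with the 1-phenyl-1H-tetrazol-5-yl group on the sulfur.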